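Side-chain aryl swaps, from compound 2 to compound 3

A few compounds are considered here, and "the series" means these few. Any claim that something is new, unique, unknown or untested is made for them only; others in the source may bear on it.

Measured in a functional assay on KB cells (Homo sapiens) for cytotoxicity; a higher number here means that more compound is needed for the effect, a lower number that less compound is needed:
compound 1 `COC1=C(C)C(=O)/C(=C(O)/C=C/c2cccc(OC)c2)C(=O)C1(C)C`: 2.4 ug/mL
compound 2 `C=Cc1ccccc1/C=C/C(O)=C1/C(=O)C(C)=C(OC)C(C)(C)C1=O`: 1.1 ug/mL

Of the two numbers, compound 2 has the lower, 1.1 ug/mL. The next structure is compound 3 `COC1=C(C)C(=O)/C(=C(O)/C=C/c2cccs2)C(=O)C1(C)C`: thiophen-2-yl in place of 2-vinylphenyl on a double-bonded chain carbon bound to a double-bonded chain carbon. Within the data shown here, the only measured step at this place is modest: a 2.2-fold lower number from compound 1 to compound 2 (0.34 log units; beyond the scatter). Among the measured compounds shown here, no thiophen-2-yl compound has been measured, so this step gives only a rough guide to size. The expected step is a 1.8-fold higher number from compound 2 to compound 3 (0.26 log units; within the scatter), similar in size to the measured one and toward a higher number. Compound 3 is estimated at 2 ug/mL, with an expected range of 0.8 ug/mL to 5 ug/mL.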

Compound 3, concentration for half-maximal effect: 3.4 ug/mL
Estimate against measurement, compound 3: 1.7-fold (0.23 log units) below; the measured number falls inside the stated range.
By their numbers in this assay, from the lowest: compound 2; then compounds 1 and 3 (each within the scatter of the next).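

At this place, on a double-bonded chain carbon bound to a double-bonded chain carbon, this assay now compares a five-membered aromatic ring with two six-membered ones: thiophen-2-yl gives a 3.1-fold higher number from compound 2 to compound 3 (0.49 log units; beyond the scatter), but only a 1.4-fold higher number from compound 1 to compound 3 (0.15 log units; within the scatter). Thus 2-vinylphenyl alone stands apart among the three, while thiophen-2-yl and 3-methoxyphenyl cannot be told apart. No evidence bearing on the cause is available. Open, from the compounds shown here alone, is whether an aryl group carrying an amine or a carboxylic acid would shift the number at this place.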